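The source may hold more compounds than are shown below. What is called first, only, known or untested is meant among the compounds shown, and "the series" means these compounds.

Measured so far in a functional assay on OVCAR-8 cells (Homo sapiens); a higher number here means a weaker inhibitor of growth, a lower number a stronger inhibitor of growth:

Compound 1 `O=S(=O)(/C=C/c1ccc(Cl)cc1Cl)Cc1ccc(Nc2ncnc3ccccc23)cc1` gives 4000 nM.
Compound 2 `O=S(=O)(/C=C/c1ccc(F)cc1Cl)Cc1ccc(Nc2ncnc3ccccc23)cc1` gives 100000 nM.
Compound 3 `O=S(=O)(/C=C/c1ccc(F)cc1Cl)Cc1ccc(Nc2ncnc3cc(Cl)ccc23)cc1` gives > 100000 nM, which is a limit of the assay and not a number.

The change from compound 1 to compound 2, (fluoro in place of chloro on an aromatic carbon), produced a 25-fold higher number from compound 1 to compound 2 (1.40 log units; beyond the scatter). From compound 2 to compound 3 the change is chloro in place of hydrogen on an aromatic carbon, with a number no lower from compound 2 to compound 3 (the limit leaves the size open). Compound 3 stands at the limit of > 100000 nM in this assay, at which 1 of the 3 values shown sits. How the core of compound 1 and the core of compound 3 differ is not broken down here.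

Compound 4 `O=S(=O)(/C=C/c1ccc(F)cc1F)Cc1ccc(Nc2ncnc3cc(Cl)ccc23)cc1` differs from compound 3 by fluoro in place of chloro on an aromatic carbon. This is the same kind of change as from compound 1 to compound 2, but not the same: there the place was meta to a chloro group and para to a large group, here it is ortho to a large group and meta to a fluoro group. Since compound 3 already sits at a limit, compound 4 is expected to give a step that the limit leaves unreadable from compound 3 to compound 4, most likely again only a limit. The estimate for compound 4 is 200000 nM, expected between 60000 nM and 800000 nM.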

Compound 4, concentration for 50% growth inhibition: > 100000 nM
Compound 4: a limit, no number; the forecaster's own chance of this, stated with the estimate: 85%; the middle value is on the limit's open side.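

Compound 3 and compound 4 both sit at a limit of the assay and give no number, so no step can be read between them: (the limit of > 100000 nM in this assay, at which 2 of the 4 values shown sit). The compounds shown leave open where their true values lie and whether those values differ at all.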